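This account rests on a few compounds, and the source may have more. Where it says the series, first, only, none or still open, it means among the compounds named here.

Compound 1: `O=S(=O)(c1ccc(F)cc1)c1nc2ccccc2nc1N1CCCC(O)C1` gives 2130 nM in a functional assay on PC-3 cells (Homo sapiens) for cytotoxicity, read by MTT assay, with a stated time of 72 h; a lower number here means a stronger inhibitor, a higher number a weaker inhibitor.
Compound 2: `COc1ccc(S(=O)(=O)c2nc3ccccc3nc2N2CCC(O)CC2)cc1` gives 9730 nM in this assay.

Among these two numbers compound 2 stands highest, so it is the weaker inhibitor of the pair; the nearest number belongs to compound 1, whose value is lower by an amount beyond the usual scatter of repeated measurements. Going by the values given here, both compounds share the same core and differ in two places at once, so the two values show only that compound 1 inhibits more strongly, not which change carries that gain.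

Compound 3, `O=S(=O)(c1ccc(F)cc1)c1nc2ccccc2nc1N1CCC(O)CC1`, keeps the ring-bound alcohol of compound 2 and changes only the group on the outer aromatic ring: fluoro in place of methoxy on an aromatic carbon. This is the same outer ring that compound 1 carries, so compound 3 sits between the two measured compounds in structure. Among the compounds with values here, with no measured pair that isolates this single change, a modest shift is expected in this assay, towards a lower number, leaning on the lower value of compound 1 at 2130 nM. The expected step is a 2.2-fold lower number from compound 2 to compound 3 (0.33 log units; beyond the scatter). For compound 3 the estimated value is 4500 nM, within a range from 1500 nM to 13000 nM.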

Compound 3, half-maximal inhibitory concentration: 2010 nM
Compound 3: the middle estimate sits 2.2-fold (0.35 log units) above what was measured; the range from low to high includes it.
By their numbers in this assay, from the lowest: compounds 3 and 1 (each within the scatter of the next); then compound 2.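

In this assay, fluoro in place of methoxy on the aromatic carbon para to a large group gives a 4.8-fold lower number from compound 2 to compound 3 (0.68 log units; beyond the scatter) and so lies beyond the scatter, which shows that this one change alone is enough to separate the two compounds. Exchanging 3-hydroxypiperidin-1-yl for 4-hydroxypiperidin-1-yl gives a 1.1-fold lower number from compound 1 to compound 3 (0.03 log units; within the scatter) and lies within the scatter, so with the 4-fluorophenyl group in place these two alcohol-bearing rings cannot be told apart. The gap between compound 1 and compound 2, which differ in two places, can now be traced among these three compounds to the 4-methoxyphenyl to 4-fluorophenyl change rather than to the hydroxypiperidine change.

On these data alone, only methoxy and fluoro appear at this position, so it remains open whether chloro, a nitrile or plain hydrogen would behave like fluoro, and whether the two hydroxypiperidines would still match with methoxy on the outer ring. Nothing measured alongside these numbers bears on why the fluoro compound gives the lower value.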